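This account rests on a few compounds, and the source may have more. Where it says the series, first, only, none or still open, it means among the compounds named here.

Series notes. Compound 1 `CC(C)=CCC/C(C)=C/CC1Cc2c(OCC=C(C)C)cc(=O)n(CCCO)c2CC1(C)C` gives 15.9% in a functional assay on PANC-1 cells (Homo sapiens) for inhibition, read by MTT assay, with a stated time of 24 h, tested at 10 uM; on this read-out higher numbers stand for more inhibition at the one concentration tested (going by the name of the read-out) and lower numbers for less inhibition; compound 2 `CC(C)=CCC/C(C)=C/CC1Cc2c(OCCCNS(=O)(=O)c3ccc(Cl)cc3)cc(=O)n(CCCO)c2CC1(C)C` gives 16.1% in this assay; compound 3 `CC(C)=CCC/C(C)=C/CC1Cc2c(OCCCNC(=O)c3ccc([N+](=O)[O-])cc3)cc(=O)n(CCCO)c2CC1(C)C` gives 6.5% in this assay. Compound 3 is the lowest of the three numbers shown, though both gaps to it lie within the scatter, so no order among the three is claimed. Among the compounds with values here, the only measured step, a number 9.6 percentage points lower from compound 2 to compound 3 (within the scatter), exchanges the group on the amine nitrogen and stays within the scatter. Compound 4 `CC(C)=CCC/C(C)=C/CC1Cc2c(OCCCOc3ccc([N+](=O)[O-])cc3)cc(=O)n(CCCO)c2CC1(C)C` differs from compound 3 by 4-nitrophenoxy in place of ((4-nitrophenyl)carbonyl)amino on a saturated chain carbon, three bonds along the chain from an oxygen on an aromatic ring. Within the data shown here, no measured step covers this exchange; the single step available is within the scatter. A step of a number 2.5 percentage points higher from compound 3 to compound 4 (within the scatter) is therefore expected, nothing beyond the scatter. The estimate for compound 4 is 9%, with a range from 0% to 20%.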

Compound 4, a percentage reported as inhibition, at one concentration (the size of the read-out at that concentration, not a potency): 9.8%
Estimate against measurement, compound 4: 0.8 percentage points below, and the stated range covers the measured number.
By their numbers in this assay, from the lowest: compounds 3, 4, 1 and 2 (each within the scatter of the next).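

On the saturated chain carbon, 4-nitrophenoxy in place of ((4-nitrophenyl)carbonyl)amino gives a number 3.3 percentage points higher from compound 3 to compound 4 (within the scatter) in this assay, so this exchange, which removes the amide hydrogen and the carbonyl, yields no separation. The comparisons with the other two groups, a number 6.3 percentage points lower from compound 2 to compound 4 (within the scatter) and a number 6.1 percentage points lower from compound 1 to compound 4 (within the scatter), also yield none, and the four compounds remain unordered. No evidence bears on this result. Open, as far as these compounds go, is whether any group at this position separates from these four, for example an amine, a carboxylic acid or a longer chain ending in 4-nitrophenoxy.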